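Swapping Cyclohexyl for Benzyl: Expected Effect on Cell Inhibition

The source may hold more compounds than are shown below. What is called first, only, known or untested is meant among the compounds shown, and "the series" means these compounds.

Measured compounds:
compound 1, `CC(=O)c1ccc(-c2cn3ccnc3c(-c3ccc4ncn(C5CCCCC5)c4c3)n2)cc1` — 0.73%
compound 2, `c1cn2cc(-c3ccc4c(c3)ncn4C3CCCCC3)nc(-c3ccc4ncn(C5CCCCC5)c4c3)c2n1` — 14.9%

Of the compounds shown here, two have been measured in a functional assay on MDA-MB-468 cells (Homo sapiens) for inhibition, read by sulforhodamine B assay, with a stated time of 48 h, tested at 10 uM; a lower number here means less inhibition, a higher number more inhibition at the concentration tested (going by the name of the read-out). Compound 1 gives 0.73%, a reading that sits close to no inhibition at all. Compound 2 gives 14.9%, the higher of the two numbers, and its gap to compound 1 lies beyond the usual scatter of repeated measurements, so compound 2 does stand above compound 1 in this assay.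

Compound 3, `c1ccc(Cn2cnc3ccc(-c4nc(-c5ccc6c(c5)ncn6C5CCCCC5)cn5ccnc45)cc32)cc1`, has not yet been measured. It differs from compound 2 in one place: benzyl in place of cyclohexyl on an aromatic nitrogen. Both groups carry a single six-membered ring of carbon only, and neither brings a hydrogen-bond donor or acceptor, so the two structures are closely matched in what is counted.

Within the data shown here, no measured pair shows this change, so its direction cannot be read from the data. The expectation is a step of no size beyond the scatter. Compound 3 is therefore expected to give about 15%, with a range from 0% to 35%. The expected step of a number 0.1 percentage points higher from compound 2 to compound 3 (within the scatter) is estimated to be small.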

Compound 3, a percentage reported as inhibition, at one concentration (the size of the read-out at that concentration, not a potency) in the MDA-MB-468 assay: -35.7%
Estimate against measurement, compound 3: 50.7 percentage points above; measured number outside the range, below it.
By their numbers in the MDA-MB-468 assay, from the lowest: compound 3; then compound 1; then compound 2.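

Among these compounds, in the MDA-MB-468 assay, the swap of cyclohexyl for benzyl on an aromatic nitrogen gives a number 50.6 percentage points lower from compound 2 to compound 3 (beyond the scatter), the first sign that the reading in this cell assay depends on the group at this position, even though cyclohexyl has 6 heavy atoms and benzyl 7 heavy atoms and both carry one six-membered ring of carbon only. In a physicochemical assay for lipophilicity, using the shake flask method, in phosphate buffer, measured as octanol-water partition, with a stated time of 85 min, at pH 7.4 (on this read-out higher numbers stand for higher lipophilicity and lower numbers for lower lipophilicity), compound 2 gives 1.9 and compound 3 gives 1.61, and the same swap gives a number 0.29 log units lower from compound 2 to compound 3 (within the scatter), so this partition measurement does not separate compound 2 from compound 3 the way the cell assay does. The data shown offer no measured explanation for the large step in the cell assay.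

One swap at one position cannot show whether the step follows the aromatic ring of benzyl or its additional carbon, and a phenyl group on the same aromatic nitrogen would help separate those two features. Also open is how this position responds to a small group such as methyl, or to a ring carrying an amine such as piperidine, since the compounds shown place only cyclohexyl or benzyl there.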